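The source may hold more compounds than are shown below. What is called first, only, known or untested is meant among the compounds shown, and "the series" means these compounds.

Measured compounds:

compound 1 `Nc1nc(Cl)c2ncn(Cc3ccc(CCl)cc3)c2n1` — 85100 nM
compound 2 `ClCc1cccc(Cn2cnc3c(Cl)nc(Cl)nc32)c1` — 6600 nM
compound 3 `ClCc1ccc(Cn2cnc3c(Cl)nc(Cl)nc32)cc1` — 25100 nM

All three were run in a functional assay on A498 cells (Homo sapiens) for cytotoxicity, read by sulforhodamine B assay, with a stated time of 48 h; on this read-out higher numbers stand for weaker inhibition of growth and lower numbers for stronger inhibition of growth. Within this set compound 2 gives the lowest number, 6600 nM; compound 3 sits at 25100 nM and compound 1 at 85100 nM, each of the gaps to compound 2 being beyond the scatter. Compound 2 and compound 3 are built from the same atoms joined differently; the difference between the two cores is not broken down here.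

One change is seen once with a measurement: from compound 3 to compound 1 the change is amino in place of chloro on an aromatic carbon, and in this assay it gave a 3.4-fold higher number from compound 3 to compound 1 (0.53 log units; beyond the scatter).

Compound 4 `Nc1nc(Cl)c2ncn(Cc3cccc(CCl)c3)c2n1` is not yet measured. Among the measured compounds shown here, it is related to compound 2 by amino in place of chloro on an aromatic carbon, which is the same change as the one from compound 3 to compound 1, at the same place in the same words. For the measured compounds named here, since the core of compound 2 is the one that gave the lowest number, the expectation rests on carrying the single known step over: from compound 2 to compound 4 a step of a 3.3-fold higher number from compound 2 to compound 4 (0.52 log units; beyond the scatter) is expected, set beside the measured 3.4-fold higher number from compound 3 to compound 1 (0.53 log units; beyond the scatter). Going by the values given here, only one instance of the change is measured, so the width allowed for is wide. In this assay compound 4 is thus estimated at 22000 nM, expected to fall between 9000 nM and 55000 nM.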

Compound 4, concentration for total growth inhibition: 51300 nM
For compound 4 the middle estimate is 2.3-fold (0.37 log units) below the measured one; the range from low to high includes it.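

In this assay, amino in place of chloro on an aromatic carbon again gives a higher number on the second core, a 7.8-fold higher number from compound 2 to compound 4 (0.89 log units; beyond the scatter), so the change moves the read-out towards weaker inhibition of growth in both measured pairs. The two steps cannot be told apart in size: the same change on two cores in this assay, a 3.4-fold higher number (0.53 log units; beyond the scatter) from compound 3 to compound 1 and a 7.8-fold higher number (0.89 log units; beyond the scatter) from compound 2 to compound 4, 2.3-fold (0.36 log units) apart, within the scatter of two such steps. Among the compounds shown here, this supports carrying the change between these two cores in both direction and approximate size, but it rests on only two pairs in one cell line and one read-out, and it shows neither why the change has this effect nor how it would behave on any other core.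

The compounds shown leave open whether the trend is specific to amino or extends to other replacements at that aromatic carbon, such as a methoxy group, a methylamino group or a morpholine ring. They also leave open what happens when the chloro group retained in compound 1 and compound 4 is itself exchanged, for example for an amine or a methoxy group, so the contribution of that second position remains undefined in this series.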